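A basic chain replaces the benzamide on the amine

The source may report more compounds than this note shows. Statements on the series, on what has been measured and on what is new or still open speak of the compounds shown alone.

Compound 1, `Nc1ccc(Nc2c(C(=O)NCc3ccc(F)cc3)nc(Br)c3cccnc23)cc1`: 10000 nM
Compound 2, `C[C@@H](Nc1c(C(=O)NCc2ccc(F)cc2)nc(Br)c2cccnc12)c1ccccc1`: > 20000 nM
Compound 3, `O=C(NCCCNc1c(C(=O)NCc2ccc(F)cc2)nc(Br)c2cccnc12)c1ccccc1`: > 10000 nM

In a functional assay on HCT-116 cells (Homo sapiens) for cytotoxicity, read by MTT assay, with a stated time of 72 h (on this read-out higher numbers stand for weaker inhibition and lower numbers for stronger inhibition), compound 1 gives 10000 nM. Compound 2 reaches only a limit of the assay, > 20000 nM. Compound 3 likewise returns only a limit, > 10000 nM, so its standing among the three is fixed no further than that it sits at the limit of > 10000 nM in this assay, at which 1 of the 3 values shown sits, while another compound sits at the limit of > 20000 nM in this assay, at which 1 of the 3 values shown sits. None of the three compounds yields a number that sets it apart.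

Compound 4, `NCCCCCCNc1c(C(=O)NCc2ccc(F)cc2)nc(Br)c2cccnc12`, differs from compound 3 by 3-aminopropyl in place of benzamido on a saturated chain carbon, three bonds along the chain from a nitrogen on an aromatic ring. Among the measured compounds shown here, the only measured step, an at least 2.0-fold higher number from compound 1 to compound 2 (0.30 log units; that floor lies within the scatter), concerns a different place and is itself no larger than the scatter; no measured step covers the present change. For compound 4 the expectation in this assay is therefore a step of no size beyond the scatter, a number no higher from compound 3 to compound 4 (the limit leaves the size open). The estimate for compound 4 in this assay is 10000 nM, expected to lie between 3000 nM and 30000 nM, with a real chance that only a limit is reported again.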

Compound 4, half-maximal inhibitory concentration: 7000 nM
The estimate for compound 4 lay 1.4-fold (0.15 log units) above the measured number, and the stated range covers the measured number.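

Putting 3-aminopropyl in place of benzamido gives an at least 1.4-fold lower number from compound 3 to compound 4 (0.15 log units; that floor lies within the scatter), so this change turns a limit into a number in this assay but shows no gain that can be claimed. On the nitrogen on an aromatic ring, 6-aminohexyl in place of 1-phenylethyl gives an at least 2.8-fold lower number from compound 2 to compound 4 (0.45 log units; beyond the scatter), the only step among these compounds that clears the scatter, so the group at this place can move the number. Putting 6-aminohexyl in place of 4-aminophenyl gives a 1.4-fold lower number from compound 1 to compound 4 (0.15 log units; within the scatter), so these two groups cannot be told apart in this assay.

On these data alone, how far compound 4 truly stands from compound 3 remains open, since compound 3 gives only a limit: the limit of > 10000 nM in this assay, at which 1 of the 4 values shown sits. As far as these compounds go, whether a longer chain, or a carboxylic acid in place of the amine, would shift the number beyond the scatter also remains open.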